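The compounds below may be only part of what the source reports. "The series", "measured", "known", "first", "only" and "open" are said of these compounds alone.

Of the compounds shown here, three sharing one core have been measured in an assay on cells (Endothelial cell) for binding affinity to Endothelin-1 receptor (Sus scrofa); a higher number here means a weaker inhibitor, a lower number a stronger inhibitor. Compound 1 `COc1cccc(Oc2c(NS(=O)(=O)c3ccc(C(C)(C)C)cc3)ncnc2OCCOc2ccncn2)c1` gives 1.2 nM, compound 2 `COc1cccc(Oc2c(NS(=O)(=O)c3ccc(C(C)(C)C)cc3)ncnc2OCCOc2nccs2)c1` gives 12 nM, and compound 3 `COc1cccc(Oc2c(NS(=O)(=O)c3ccc(C(C)(C)C)cc3)ncnc2OCCOc2ncc(C)cn2)c1` gives 0.86 nM. Compound 3 has the lowest number of the three, yet compound 1 sits so close to it that the two cannot be told apart, because a 1.4-fold lower number from compound 1 to compound 3 (0.14 log units; within the scatter). Compound 2 stands apart: a 10-fold higher number from compound 1 to compound 2 (1.00 log units; beyond the scatter) and a 14-fold lower number from compound 2 to compound 3 (1.14 log units; beyond the scatter).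

Compound 4 `COc1cccc(Oc2c(NS(=O)(=O)c3ccc(C(C)(C)C)cc3)ncnc2OCCOc2nccc(C)n2)c1` has not been measured. It differs from compound 3 by 4-methylpyrimidin-2-yl in place of 5-methylpyrimidin-2-yl on an oxygen on a saturated carbon. For the measured compounds named here, no measured pair tests where the methyl sits on the same ring, so the bearing of the earlier steps is indirect. The swap of the whole ring in the step from compound 1 to compound 3 stayed within the scatter, whereas the steps involving compound 2 were large. Shifting a methyl on an otherwise unchanged ring is expected to matter less than exchanging the ring, so the step of a 1.7-fold higher number from compound 3 to compound 4 (0.24 log units; within the scatter) is estimated to stay near or within the scatter. Compound 4 is therefore expected to give 1.5 nM in this assay, with a range from 0.5 nM to 5 nM.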

Compound 4, half-maximal inhibitory concentration: 39.4 nM
The estimate for compound 4 lay 26-fold (1.42 log units) below the measured number; the whole stated range lies below it.
By their numbers in this assay, from the lowest: compounds 3 and 1 (each within the scatter of the next); then compound 2; then compound 4.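

Moving one methyl on an otherwise unchanged ring, with the same atoms and the same counted features, gives a 46-fold higher number from compound 3 to compound 4 (1.66 log units; beyond the scatter) in this assay, so at this position the place of a single methyl on the ring can matter as much as exchanging the whole ring. Keeping a methylpyrimidin-2-yl group therefore does not by itself keep the low number: 4-methylpyrimidin-2-yl also compares poorly with 1,3-thiazol-2-yl, at a 3.3-fold higher number from compound 2 to compound 4 (0.52 log units; beyond the scatter), and with pyrimidin-4-yl, at a 33-fold higher number from compound 1 to compound 4 (1.52 log units; beyond the scatter). Nothing available here explains this difference.

On these data alone, it stays open whether pyrimidin-2-yl carrying no methyl would sit nearer compound 3 or compound 4. Also open, as far as these compounds go, is whether an ethyl or an amine in place of the methyl in 4-methylpyrimidin-2-yl would give a similarly high number.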